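The source may report more compounds than this note shows. Statements on the series, on what has been measured and on what is new or still open speak of the compounds shown alone.

Working notes on the series. Of the compounds shown here, three with a shared core have been measured in a functional assay on WM 266-4 cells (Homo sapiens) for antiproliferative activity, read by MTT assay, with a stated time of 24 h; on this read-out higher numbers stand for weaker inhibition of growth and lower numbers for stronger inhibition of growth. Compound 1 `COc1ccc(C2=NN(C(=O)c3ccc(C)nc3Cl)C(c3ccc(Br)cc3)C2)cc1` gives 8470 nM. Compound 2 `COc1ccc(C2=NN(C(=O)c3cncc(Br)c3)C(c3ccc(OCc4ccccc4)cc3)C2)cc1` gives 6240 nM. Compound 3 `O=C(c1cncc(Br)c1)N1N=C(c2ccc(Cl)cc2)CC1c1ccc(OCc2ccccc2)cc1` gives 8130 nM. Going by the values given here, the single one-place step measured so far, a 1.3-fold higher number from compound 2 to compound 3 (0.11 log units; within the scatter), is a chloro in place of a methoxy on an aromatic carbon. Compound 3 therefore sits with the other two in a narrow band: its number is second highest of the three, and its distance to compound 1 and to compound 2 is in each case within the scatter, so no order among them can be read.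

Compound 4 `Cc1ccc(C(=O)N2N=C(c3ccc(Cl)cc3)CC2c2ccc(OCc3ccccc3)cc2)c(Cl)n1` is not yet measured. It differs from compound 3 in one place: 2-chloro-6-methylpyridin-3-yl in place of 5-bromopyridin-3-yl on a carbonyl carbon. Among the compounds with values here, no measured step bears directly on this change. Compound 1 carries the entering group and compound 2 carries the leaving group on the same carbonyl carbon, but those two compounds also differ elsewhere, so only their values can be set beside each other, and they lie close together. On that basis compound 4 is expected to give a number in the same band as compound 3, with a step of a 1.0-fold higher number from compound 3 to compound 4 (0.02 log units; within the scatter) expected to stay within the scatter. The estimate for compound 4 in this assay is 8500 nM, with a range from 4000 nM to 18000 nM.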

Compound 4, concentration for 50% growth inhibition: 11400 nM
Beside the measured number, compound 4's estimate is 1.3-fold (0.13 log units) below it, within the range that was stated.
By their numbers in this assay, from the lowest: compounds 2, 3, 1 and 4 (each within the scatter of the next).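

In this assay, going by these compounds alone, the exchange of 5-bromopyridin-3-yl for 2-chloro-6-methylpyridin-3-yl on the carbonyl carbon gives a 1.4-fold higher number from compound 3 to compound 4 (0.15 log units; within the scatter), the first measured one-place step at this position, and it shows that these two groups cannot be told apart in this read-out when the rest of the molecule is held constant. Within the data shown here, the single step replaces the bromine with a chlorine and adds a methyl group, so it gives no separate reading for either feature; it shows only that the combined exchange leaves the pair within the scatter. No supporting measurement bears on why the two groups read alike, and none is available to connect this result to any property of either group.

From the compounds shown here alone, whether any group on this carbonyl carbon can move the number beyond the scatter remains open, since both groups seen here are halogen-bearing pyridinyl rings. An amine or a carboxylic acid on the six-membered aromatic ring, or a plain phenyl ring in its place, would test that question, as would the methyl group and the chlorine taken separately.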